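Swapping phenoxy for trifluoromethyl on a weak cytotoxic scaffold

The compounds below may be only part of what the source reports. "The series", "measured", "known", "first", "only" and "open" are said of these compounds alone.

Measured so far:
compound 1 `N#CC1=C(N)OC2=C(C(=O)CCC2)C1c1cc(F)cc(F)c1` gives 164 ug/mL
compound 2 `CC1(C)CC(=O)C2=C(C1)OC(N)=C(C#N)C2c1cccc(Oc2ccccc2)c1` gives 481 ug/mL

In a functional assay on 4T1 cells (Mus musculus) for cytotoxicity, read by MTT assay, with a stated time of 48 h (a lower number here means a stronger inhibitor, a higher number a weaker inhibitor), compound 2 stands at the highest of the two numbers, with compound 1 at a lower number, a gap beyond the usual scatter. Compound 3 `CC1(C)CC(=O)C2=C(C1)OC(N)=C(C#N)C2c1cccc(C(F)(F)F)c1` shares the core of compound 2 but differs in one place: trifluoromethyl in place of phenoxy on an aromatic carbon. Among the compounds with values here, no measured pair shows this exact change, so no step size is established. A modest move toward a lower number is expected, a 1.6-fold lower number from compound 2 to compound 3 (0.21 log units; within the scatter), though one within or near the scatter would not surprise. Compound 3 is estimated at 300 ug/mL, with a range from 100 ug/mL to 900 ug/mL.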

Compound 3, half-maximal inhibitory concentration: 287 ug/mL
Estimate against measurement, compound 3: 1.0-fold (0.02 log units) above, and the stated range covers the measured number.
By their numbers in this assay, from the lowest: compounds 1, 3 and 2 (each within the scatter of the next, the first and the last beyond it).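

In this assay the swap of phenoxy for trifluoromethyl on this aromatic carbon gives a 1.7-fold lower number from compound 2 to compound 3 (0.22 log units; within the scatter) and so removes a whole six-membered aromatic ring without a clear shift in the read-out. At this position, then, the smaller group without a ring and the larger group with one cannot be told apart. Nothing measured here explains why the two groups read alike. On these data alone, whether an amine or a carboxylic acid on the same aromatic carbon would move the number beyond the scatter remains open.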